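Thiophene for pyrimidine: solubility across the biaryl amides

A few compounds are considered here, and "the series" means these few. Any claim that something is new, unique, unknown or untested is made for them only; others in the source may bear on it.

Compound 1 `CCCOc1ccc(C[C@@H](Cc2ccccc2)C(=O)O)cc1CNC(=O)c1ccc(-c2cncnc2)cc1` carries a pyrimidin-5-yl ring on the phenyl of the amide. In a physicochemical assay for solubility, read by HPLC, in phosphate buffer, measured as thermodynamic solubility, with a stated time of 48 h, at pH 7.2 (on this read-out lower numbers stand for lower solubility and higher numbers for higher solubility), compound 1 gives 190 ug/mL, the highest of the two numbers recorded in the series. Compound 2 `CCCOc1ccc(C[C@@H](Cc2ccccc2)C(=O)O)cc1CNC(=O)c1ccc(-c2cnccn2)cc1`, with pyrazin-2-yl in that place, gives 32.2 ug/mL in this assay. Compound 3 `CCCOc1ccc(C[C@@H](Cc2ccccc2)C(=O)O)cc1CNC(=O)c1ccc(-c2ccccc2F)cc1`, with 2-fluorophenyl there, reports < 1 ug/mL in this assay, which is a limit of the assay and not a number (the limit of < 1 ug/mL in this assay, at which 1 of the 3 values shown sits). The measured steps are a 5.9-fold lower number from compound 1 to compound 2 (0.77 log units; beyond the scatter) and an at least 190-fold lower number from compound 1 to compound 3 (2.27 log units; beyond the scatter); between the two replacements, an at least 32-fold lower number from compound 2 to compound 3 (1.50 log units; beyond the scatter).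

Compound 4 `CCCOc1ccc(C[C@@H](Cc2ccccc2)C(=O)O)cc1CNC(=O)c1ccc(-c2cccs2)cc1` is the unmeasured member: thiophen-2-yl in place of pyrimidin-5-yl on an aromatic carbon. Both measured steps away from compound 1 bear on this change, the modest 5.9-fold lower number from compound 1 to compound 2 (0.77 log units; beyond the scatter) and the large at least 190-fold lower number from compound 1 to compound 3 (2.27 log units; beyond the scatter), and the thiophen-2-yl ring stands nearer to the 2-fluorophenyl of compound 3 than to the pyrazin-2-yl of compound 2 in what is counted. A fall well beyond the scatter is therefore expected in this assay. The expected step is a 130-fold lower number from compound 1 to compound 4 (2.10 log units; beyond the scatter). Compound 4 is estimated at 1.5 ug/mL, with a range from 0.4 ug/mL to 6 ug/mL, and a fair chance that the assay reports only a limit.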

Compound 4, solubility: < 1 ug/mL
Compound 4 ended at the assay's limit; the forecaster's own chance of this, stated with the estimate: 40%; at least 1.5-fold (0.17 log units) between middle value and limit.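

Thiophen-2-yl in place of pyrimidin-5-yl on this aromatic carbon gives an at least 190-fold lower number from compound 1 to compound 4 (2.27 log units; beyond the scatter) and an at least 32-fold lower number from compound 2 to compound 4 (1.50 log units; beyond the scatter); both steps end at a limit of the assay, so they give a lower bound on the fall and not its full size. For the compounds shown here, the position therefore tolerates a second ring without ring nitrogen no better than it tolerated the 2-fluorophenyl of compound 3, and among the four compounds only the pyrimidin-5-yl and pyrazin-2-yl rings return a readable number, with no compound going against this: the limit of < 1 ug/mL in this assay, at which 2 of the 4 values shown sit. The step from compound 3 to compound 4 cannot be read, as both ends are limits, so the five-membered and six-membered rings without ring nitrogen cannot be ordered.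

On these data alone, whether a single ring nitrogen at this place, as in a pyridin-3-yl or thiazol-5-yl ring, would bring the number back above the limit remains open. Also open, as far as these compounds go, is whether an amine such as morpholine on the thiophen-2-yl ring would recover a readable number in this assay.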